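The source may hold more compounds than are shown below. What is called first, only, known or untested is meant among the compounds shown, and "the series" means these compounds.

Compound 1 `CN(C)CCn1cnnc1-c1cc(Oc2ccc(NC(=O)N/N=C/c3ccccc3O[N+](=O)[O-])cc2F)ccn1` gives 7150 nM in a functional assay on U-87MG ATCC cells (Homo sapiens) for cytotoxicity, read by MTT assay, with a stated time of 72 h; a higher number here means a weaker inhibitor, a lower number a stronger inhibitor. Compound 2 `CN(C)CCn1cnnc1-c1cc(Oc2ccc(NC(=O)N/N=C/c3ccc(O)c(F)c3)cc2F)ccn1` reaches only the limit of > 100000 nM in this assay, and that is a limit, not a number (the limit of > 100000 nM in this assay, at which 1 of the 2 values shown sits). Within the data shown here, the one measured step, an at least 13-fold higher number from compound 1 to compound 2 (1.14 log units; beyond the scatter), weakens inhibition. Among the measured compounds shown here, compound 3 `COc1ccc(/C=N/NC(=O)Nc2ccc(Oc3ccnc(-c4nncn4CCN(C)C)c3)c(F)c2)cc1O` differs from compound 2 by 3-hydroxy-4-methoxyphenyl in place of 3-fluoro-4-hydroxyphenyl on a carbon with a double bond to nitrogen, a change that no measured step mirrors, so the expectation rests only on compound 2 standing at the limit. Compound 3 is therefore expected to remain weak, estimated at 60000 nM, between 15000 nM and 200000 nM, a step of an at least 1.6-fold lower number from compound 2 to compound 3 (0.22 log units; that floor lies within the scatter).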

Compound 3, half-maximal inhibitory concentration: > 100000 nM
Compound 3: only a limit was reported; the forecaster's own chance of this, stated with the estimate: 55%; middle value at least 1.6-fold (0.22 log units) from the limit.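

Putting 3-hydroxy-4-methoxyphenyl in place of 2-(nitrooxy)phenyl on a carbon with a double bond to nitrogen gives an at least 13-fold higher number from compound 1 to compound 3 (1.14 log units; beyond the scatter) in this assay, so a second replacement at this place, not only 3-fluoro-4-hydroxyphenyl, goes with a large loss. The step from compound 2 to compound 3 cannot be read, since both values are limits and not numbers. The limit now holds most of the series: the limit of > 100000 nM in this assay, at which 2 of the 3 values shown sit.

From the compounds shown here alone, compound 1 alone gives a number, so what separates the two replacements stays open. Also open, going by these compounds, is whether plain phenyl or an aminophenyl at this place would give a number in this assay.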